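The compounds below may be only part of what the source reports. "The series", "measured", "known", "first", "only" and "open" are said of these compounds alone.

The measured compounds, in order:

Compound 1 `C/C(=N\Nc1nc(-c2ccccc2)cs1)c1sc(C)nc1C` gives, in a toxicity assay on MCF7 cells (Homo sapiens) for cytotoxicity, read by MTT assay (a higher number here means a weaker inhibitor of growth, a lower number a stronger inhibitor of growth), a value of > 100 ug/mL, which is a limit of the assay and not a number.
Compound 2 `C/C(=N\Nc1nc(-c2ccc(Cl)cc2)cs1)c1sc(C)nc1C` gives in this assay a value of > 100 ug/mL, likewise a limit.
Compound 3 `C/C(=N\Nc1nc(-c2ccccc2)cs1)c1sc(-c2ccccc2)nc1C` gives in this assay a value of > 100 ug/mL, again only a limit.

Compound 3 therefore stands nowhere in particular on a scale of numbers: its value sits at the limit of > 100 ug/mL in this assay, at which 3 of the 3 values shown sit, and the two other values shown sit at the same limit. Compound 4 `C/C(=N\Nc1nc(-c2ccc(Cl)cc2)cs1)c1sc(-c2ccccc2)nc1C` differs from compound 3 by chloro in place of hydrogen on an aromatic carbon. For the measured compounds named here, two measured steps bear on this change. The step with the same chloro for hydrogen exchange, from compound 1 to compound 2, is a step that the two limits leave unreadable from compound 1 to compound 2, and the step that built the phenyl-bearing core from compound 1 to compound 3 is a step that the two limits leave unreadable from compound 1 to compound 3. Neither step is readable, so no direction and no size can be taken from them; the only expectation left is that compound 4 also stays at the limit, and the step from compound 3 to compound 4 is estimated as a step that the limit leaves unreadable from compound 3 to compound 4. Compound 4 is accordingly expected to give about 150 ug/mL in this assay, within a range from 50 ug/mL to 450 ug/mL.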

Compound 4, concentration for 50% growth inhibition: > 100 ug/mL
Compound 4: no number, only a limit; the forecaster's own chance of this, stated with the estimate: 85%; the middle value lies beyond the limit too.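

Compound 4 gives only a limit in this assay, so no new step can be read, neither from compound 3 to compound 4 nor from compound 2 to compound 4: the limit of > 100 ug/mL in this assay, at which 4 of the 4 values shown sit.

The compounds shown leave open how strongly any of them inhibits growth, and whether chloro or phenyl shifts that inhibition at all.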